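Series notes: the step from compound 2 to compound 4

The compounds below may be only part of what the source reports. "The series", "measured", "known", "first", "only" and "open" are said of these compounds alone.

Compound 1, `CC(C)(C)c1ccc(/C=C/C(=O)c2ccc(OCC(=O)N[C@H]3CCOC3=O)cc2)cc1`, gives 6570 nM in a functional assay on DU-145 cells (Homo sapiens) for antiproliferative activity, read by MTT assay, with a stated time of 72 h; on this read-out higher numbers stand for weaker inhibition and lower numbers for stronger inhibition.
Compound 2, `O=C(CNc1ccc(Cl)cc1Cl)N[C@H]1CCOC1=O`, gives > 64000 nM in this assay; this is a limit of the assay, not a number.
Compound 3, `O=C(CNc1ccccc1Cl)N[C@H]1CCOC1=O`, gives > 64000 nM in this assay; this too is a limit of the assay.

Compound 2 therefore stands only at a limit in this assay: it sits at the limit of > 64000 nM in this assay, at which 2 of the 3 values shown sit. Among the measured compounds shown here, compound 1 is the single member with a number, and no step between compound 1 and compound 2 is computed; their two values show only that one is a number and the other a limit.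

Compound 4, `Cc1cc(Cl)ccc1NCC(=O)N[C@H]1CCOC1=O`, differs from compound 2 by methyl in place of chloro on an aromatic carbon. For the measured compounds named here, the only measured step that bears on this change is the one from compound 2 to compound 3, a step that the two limits leave unreadable from compound 2 to compound 3, whose size cannot be read. Going by the values given here, no measured step gives a size for a change at this position, so nothing beyond the scatter is expected from it. Compound 4 is expected to remain at a limit in this assay, and its estimate is 70000 nM, with a range from 30000 nM to 200000 nM. The step that the limit leaves unreadable from compound 2 to compound 4 is thus expected to be none beyond the scatter.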

Compound 4, half-maximal inhibitory concentration: > 64000 nM
Compound 4 ended at the assay's limit; the forecaster's own chance of this, stated with the estimate: 75%; the middle value is on the limit's open side.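

Compound 2 and compound 4 both stand only at a limit, not a number, in this assay, so no step between them can be read: the limit of > 64000 nM in this assay, at which 3 of the 4 values shown sit.

The compounds shown leave open what size, if any, the change from chloro to methyl on this aromatic carbon has.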